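Swapping Methoxy for Bromo on a Shared Core

The source may hold more compounds than are shown below. What is called first, only, known or untested is meant among the compounds shown, and "the series" means these compounds.

Of the compounds shown here, two have been measured in an assay on isolated protein for inhibition of phosphatidylinositol 4,5-bisphosphate 3-kinase catalytic subunit beta isoform (Homo sapiens); a higher number here means a weaker inhibitor, a lower number a stronger inhibitor. Compound 1 `COc1ccc(-c2ccnc(Nc3ccc([N+](=O)[O-])cc3)n2)cc1` gives 537 nM, and compound 2 `Clc1ccc(Nc2nccc(-c3ccc(Br)cc3)n2)c(Cl)c1` gives 673 nM. Compound 1 has the lower of the two numbers, but the gap to compound 2 lies within the scatter of this assay, so the two cannot be told apart. Compound 3 `O=[N+]([O-])c1ccc(Nc2nccc(-c3ccc(Br)cc3)n2)cc1` has not yet been measured. It differs from compound 1 in one place: bromo in place of methoxy on an aromatic carbon. Among the compounds with values here, no measured pair shows this exact change, so its effect is unknown. Since the two measured values sit close together, the step from compound 1 to compound 3 is expected to be small, likely none beyond the scatter, with a slight lean toward a higher number because compound 2 with the same bromophenyl gives 673 nM. The expected step is a 1.3-fold higher number from compound 1 to compound 3 (0.12 log units; within the scatter). Compound 3 is therefore estimated at 700 nM, with a range from 250 nM to 2000 nM.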

Compound 3, half-maximal inhibitory concentration: 961 nM
Estimate against measurement, compound 3: 1.4-fold (0.14 log units) below; the range from low to high includes it.
By their numbers in this assay, from the lowest: compounds 1, 2 and 3 (each within the scatter of the next).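

In this assay, 4-methoxyphenyl gives way to 4-bromophenyl on the shared core with a 1.8-fold higher number from compound 1 to compound 3 (0.25 log units; within the scatter). Within the data shown here, this pair isolates the change for the first time, and it shows that at this position, on an aromatic carbon para to a large group, bromo and methoxy cannot be told apart, even though one heavy atom stands in place of two and the hydrogen-bond acceptor of the methoxy is gone. Nothing measured here bears on why the two compounds read alike.

Going by these compounds, only these two groups can be compared at this position, so it remains open whether an amine, a carboxylic acid or a longer chain such as butoxy would also read alike. On these data alone, it is also open whether this swap would read the same on a core without the nitro group, such as that of compound 2.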